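The compounds below may be only part of what the source reports. "The series", "measured", "known", "first", "only" and "open" are said of these compounds alone.

Measured in a functional assay on G-361 cells (Homo sapiens) for antiproliferative activity, with a stated time of 72 h; on this read-out lower numbers stand for stronger inhibition and higher numbers for weaker inhibition:
Compound 1 `OC[C@H]1O[C@@H](n2cnc3c(NCc4ccccc4F)ncnc32)[C@H](O)[C@@H]1O`: "not determined" (no result reported).
Compound 2 `COc1ccccc1CNc1ncnc2c1ncn2[C@@H]1O[C@H](CO)[C@@H](O)[C@H]1O`: compound 2 gives only a limit of the assay, not a number, > 166000 nM.
Compound 3 `OC[C@H]1O[C@@H](n2cnc3c(NCc4ccc(Cl)cc4Cl)ncnc32)[C@H](O)[C@@H]1O`: 128000 nM.

Going by the values given here, compound 3 therefore holds the only plain number in this assay; compound 1 has no result and compound 2 ends at a limit. Among the compounds with values here, the single measured step, an at least 1.2-fold lower number from compound 2 to compound 3 (0.11 log units; that floor lies within the scatter), swaps one aryl group for another on the same chain carbon and sits within the scatter at its floor, so it shows no clear effect of such a swap.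

Compound 4 `COc1cccc(CNc2ncnc3c2ncn3[C@@H]2O[C@H](CO)[C@@H](O)[C@H]2O)c1O` differs from compound 3 by 2-hydroxy-3-methoxyphenyl in place of 2,4-dichlorophenyl on a saturated chain carbon bound to a nitrogen on an aromatic ring. The incoming group carries a methoxy group, as does the group of compound 2, and compound 2 reached only a limit (the limit of > 166000 nM in this assay, at which 1 of the 3 values shown sits). The evidence thus points to weak inhibition again, with a step from compound 3 that is expected to stay within the scatter or lean toward weaker inhibition. Compound 4 is expected to show the step of a 1.2-fold higher number from compound 3 to compound 4 (0.07 log units; within the scatter). Compound 4 is estimated at 150000 nM, within 60000 nM to 400000 nM.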

Compound 4, half-maximal inhibitory concentration: 148000 nM
Compound 4: the middle estimate sits 1.0-fold (0.01 log units) above what was measured; the measured number falls inside the stated range.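

In this assay, the aryl group on the saturated chain carbon bound to a nitrogen on an aromatic ring changes considerably: 2,4-dichlorophenyl has no hydrogen-bond donors or acceptors, whereas 2-hydroxy-3-methoxyphenyl has both, yet the result is a 1.2-fold higher number from compound 3 to compound 4 (0.06 log units; within the scatter). Going by these compounds alone, this gives the first pair of plain numbers at this position, and they show that even this change in the group's makeup does not move the number beyond the usual scatter. The other new comparison, an at least 1.1-fold lower number from compound 2 to compound 4 (0.04 log units; that floor lies within the scatter), gives only a floor, since compound 2 stays a limit and not a number: the limit of > 166000 nM in this assay, at which 1 of the 4 values shown sits.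

Whether any group at this position can give a clearly lower number remains open, since no step shown goes beyond the scatter. An amine or a carboxylic acid on the phenyl ring, or a longer chain in place of the single chain carbon, would test this.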